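A few compounds are considered here, and "the series" means these few. Any claim that something is new, unique, unknown or untested is made for them only; others in the source may bear on it.

Compound 2 is the pyranose amide carrying a short ether-terminated side chain, with the structure `CCOCCC(=O)NCC(=O)N[C@@H]1[C@@H](O)[C@H](O)[C@@H](Nc2ncnc3[nH]cnc23)O[C@H]1CO`. In a functional assay on L1210 cells (Mus musculus) for inhibition, with a stated time of 3 h (a lower number here means that less compound is needed, a higher number that more compound is needed for the effect), compound 2 gives only a limit of the assay, > 1000 uM, so its true value is not known. Compound 1, with the structure `CC(C)CCCCCCCCCCCCC(=O)N[C@@H]1[C@@H](O)[C@H](O)[C@@H](Nc2ncnc3[nH]cnc23)O[C@H]1C`, likewise reaches only a limit in this assay, > 1000 uM. For the measured compounds named here, compound 3, with the structure `CCCCCCCCCCCCCCC(=O)NCCC(=O)N[C@@H]1[C@@H](O)[C@H](O)[C@@H](Nc2ncnc3[nH]cnc23)O[C@H]1CO`, is the one compound here with a measured number, giving 93 uM in this assay. The picture so far is therefore thin: the limit of > 1000 uM in this assay, at which 2 of the 3 values shown sit.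

Compound 4, with the structure `CCCCCCCCCCCC(=O)NCC(=O)N[C@@H]1[C@@H](O)[C@H](O)[C@@H](Nc2ncnc3[nH]cnc23)O[C@H]1CO`, is the partner of compound 2 in the step followed here. The change is nonyl in place of ethoxy on a saturated chain carbon, two bonds along the chain from a carbonyl carbon. Going by the values given here, no step between measured compounds is available, so the size of this move cannot be read from the data. Still, a measurable value is expected for compound 4, because compound 3 gives 93 uM in this assay. The expected step from compound 2 to compound 4 is an at least 5.0-fold lower number from compound 2 to compound 4 (0.69 log units; beyond the scatter). Compound 4 is estimated at 200 uM, within 50 uM to 1000 uM.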

Compound 4, concentration for half-maximal effect: 5.5 uM
Estimate against measurement, compound 4: 36-fold (1.56 log units) above; the measured number lies below the stated range.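

Replacing ethoxy with nonyl on a saturated chain carbon, two bonds along the chain from a carbonyl carbon, gives an at least 180-fold lower number from compound 2 to compound 4 (2.25 log units; beyond the scatter) in this assay. For the compounds shown here, this is the first step in the set that can be read, and it shows that the group at this place matters greatly: this one change takes the compound from a limit of the assay to a measured number. Compound 2 sits at a limit and not at a number, so the step has only a lower bound: the limit of > 1000 uM in this assay, at which 2 of the 4 values shown sit.

The change alters chain length and removes the ether oxygen together, and the compounds shown do not separate the two. They also leave open what a propyl chain, an amine or a carboxylic acid would do in place of nonyl.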